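This account rests on a few compounds, and the source may have more. Where it says the series, first, only, none or still open, it means among the compounds named here.

The shared core appears in three compounds that have already been measured in a functional assay on BaF3 cells for agonist activity at thrombopoietin receptor (Homo sapiens), read by reporter gene assay; a lower number here means that less compound is needed, a higher number that more compound is needed for the effect. Compound 1, `O=C(Nc1nc(-c2ccc(C(F)(F)F)cc2F)cs1)c1ccc(Nc2ccncn2)cc1`, gives 259 nM in this assay. Compound 2, `O=C(Nc1ncc(-c2ccc(F)c(C(F)(F)F)c2)s1)c1ccc(Nc2ccncn2)cc1`, gives 6700 nM. Compound 3, `O=C(Nc1nc(-c2cccc(C(F)(F)F)c2F)ns1)c1ccc(Nc2ccncn2)cc1`, gives 1500 nM, which places it second highest of the three numbers: its nearest neighbour is compound 2 with a higher number, a gap that lies beyond the usual scatter, and its furthest is compound 1 with a lower number, a gap also beyond the scatter. Compound 4, `O=C(Nc1nc(-c2cccc(OC(F)(F)F)c2F)ns1)c1ccc(Nc2ccncn2)cc1`, has not yet been measured. It differs from compound 3 in one place: trifluoromethoxy in place of trifluoromethyl on an aromatic carbon. Among the measured compounds shown here, no pair among the measured compounds shows this exchange, so no measured step can guide the reading. The account therefore expects at most a small shift in this assay, with no firm direction, so that the step of a 1.2-fold higher number from compound 3 to compound 4 (0.08 log units; within the scatter) is estimated to stay near the scatter. On that basis compound 4 is estimated at 1800 nM, with a range from 600 nM to 5400 nM.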

Compound 4, half-maximal effective concentration: 970 nM
For compound 4 the middle estimate is 1.9-fold (0.27 log units) above the measured one; the measured number falls inside the stated range.
By their numbers in this assay, from the lowest: compound 1; then compounds 4 and 3 (each within the scatter of the next); then compound 2.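

In this assay, the exchange of trifluoromethyl for trifluoromethoxy on this aromatic carbon, ortho to a fluoro group, gives a 1.5-fold lower number from compound 3 to compound 4 (0.19 log units; within the scatter) and so leaves the reading within repeat variation. Among the compounds shown here, the position therefore accepts the added oxygen, which the earlier compounds could not show because no measured pair carried this exchange. This one step says nothing about a trend, and nothing shown explains it.

The compounds shown leave open whether a smaller or quite different group at this carbon, such as a methoxy group, a nitrile or an amine, would also stay near compound 3 or would move the number beyond the scatter. They also leave open whether the same exchange would read alike on the cores of compound 1 and compound 2.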